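Swapping the Furan Ketone for a Fluorophenyl Ketone

A few compounds are considered here, and "the series" means these few. Any claim that something is new, unique, unknown or untested is made for them only; others in the source may bear on it.

Compounds measured so far:
compound 1, `COc1cc(-c2nnc3n2NC(c2ccco2)C(C(=O)c2ccco2)S3)cc(OC)c1OC` — 68700 nM
compound 2, `COc1cc(-c2nnc3n2NC(c2ccco2)C(C(=O)c2ccc(C)cc2)S3)cc(OC)c1OC` — > 100000 nM
compound 3, `COc1cccc(C(=O)C2Sc3nnc(-c4cc(OC)c(OC)c(OC)c4)n3NC2c2ccco2)c1` — > 100000 nM

Of the compounds shown here, three sharing one core have been tested in a functional assay on A549 cells (Homo sapiens) for cytotoxicity, read by MTT assay, with a stated time of 48 h; on this read-out lower numbers stand for stronger inhibition and higher numbers for weaker inhibition. Compound 1 is the only one that yields an actual number, 68700 nM. For compound 2 the assay reports only a limit, > 100000 nM. For compound 3 it likewise reports only a limit, > 100000 nM. Both therefore sit at the limit of > 100000 nM in this assay, at which 2 of the 3 values shown sit.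

Compound 4, `COc1cc(-c2nnc3n2NC(c2ccco2)C(C(=O)c2ccc(F)cc2)S3)cc(OC)c1OC`, has not yet been measured. It differs from compound 1 in one place: 4-fluorophenyl in place of furan-2-yl on a carbonyl carbon.

Two measured steps are close relatives of this change, since each also puts a six-membered carbon ring where the furan-2-yl stood on the carbonyl carbon. Both went the same way: an at least 1.4-fold higher number from compound 1 to compound 2 (0.16 log units; that floor lies within the scatter), and an at least 1.4-fold higher number from compound 1 to compound 3 (0.16 log units; that floor lies within the scatter). Neither step can be sized, but each ends at the assay limit.

Compound 4 is therefore expected to follow them, with a 1.9-fold higher number from compound 1 to compound 4 (0.28 log units; within the scatter). The estimated value of compound 4 is 130000 nM, within a range from 50000 nM to 350000 nM, and a limit rather than a number is the more likely outcome.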

Compound 4, half-maximal inhibitory concentration: 53700 nM
Compound 4: the middle estimate sits 2.4-fold (0.38 log units) above what was measured; the range from low to high includes it.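

In this assay, a six-membered carbon ring on the carbonyl carbon does not by itself send a compound to the assay limit, as the exchange of furan-2-yl for 4-fluorophenyl gives a 1.3-fold lower number from compound 1 to compound 4 (0.11 log units; within the scatter). Compared with the other two ring-bearing ketones, the result reads as an at least 1.8-fold lower number from compound 3 to compound 4 (0.27 log units; that floor lies within the scatter) and as an at least 1.8-fold lower number from compound 2 to compound 4 (0.27 log units; that floor lies within the scatter), so these floors alone do not establish that the substituent on the ring matters. Compound 2 and compound 3 remain limits rather than numbers: the limit of > 100000 nM in this assay, at which 2 of the 4 values shown sit.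

Still open, from the compounds shown here alone, is how a plain phenyl ring on the carbonyl carbon would compare with the 4-fluorophenyl group. Also open, going by these compounds, is whether an amine or a carboxylic acid in place of the fluoro would move the value beyond the scatter.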